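The source may hold more compounds than are shown below. What is called first, only, known or untested is meant among the compounds shown, and "the series" means these compounds.

In a functional assay on HCT-116 cells (Homo sapiens) for antiproliferative activity, read by MTT assay, with a stated time of 48 h (on this read-out lower numbers stand for stronger inhibition and higher numbers for weaker inhibition), compound 1 `CCCCCCCC(CCO)n1cnc2c(N(C)C)ncnc21` gives > 50000 nM, which is a limit of the assay and not a number. Compound 2 `CCCCCCCC(CCO)n1cnc2c(N)ncnc21` is the same molecule with amino in place of dimethylamino on an aromatic carbon. In this assay compound 2 also gives > 50000 nM, again a limit rather than a number. The step between them is a step that the two limits leave unreadable from compound 1 to compound 2; its size stays hidden because of the limit of > 50000 nM in this assay, at which 2 of the 3 values shown sit. Compound 3 `CCCCCCCCC(CCO)n1cnc2c(N(C)C)ncnc21` differs from compound 1 by methyl in place of hydrogen on a saturated chain carbon, eight bonds along the chain from an aromatic nitrogen, and in this assay compound 3 gives 19800 nM; that change gave an at least 2.5-fold lower number from compound 1 to compound 3 (0.40 log units; beyond the scatter). Compound 4 `CCCCCCCCC(CCO)n1cnc2c(N)ncnc21` has not been measured. It stands to compound 3 as compound 2 stands to compound 1: amino in place of dimethylamino on an aromatic carbon, the same change at the same place, while the two cores differ as compound 1 and compound 3 do. The earlier step of this kind could not be read, so no size can be carried over from it. The expected step is a 1.6-fold higher number from compound 3 to compound 4 (0.21 log units; within the scatter), a guess that rests on compound 3 sitting at 19800 nM and on the earlier pair giving no readable step. Compound 4 is therefore estimated at 32000 nM, with a likely range from 10000 nM to 80000 nM.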

Compound 4, half-maximal inhibitory concentration: 11600 nM
Compound 4: the middle estimate sits 2.8-fold (0.44 log units) above what was measured; low and high end bracket the measured number.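

In this assay, amino in place of dimethylamino on an aromatic carbon gives a 1.7-fold lower number from compound 3 to compound 4 (0.23 log units; within the scatter), so on this core the two groups cannot be told apart. The same swap on the core of compound 1 cannot be read, so the data do not show whether its outcome carries from one core to the other, and the steps touching a limit give no exact size: the limit of > 50000 nM in this assay, at which 2 of the 4 values shown sit. From the compounds shown here alone, the other change, methyl in place of hydrogen on a saturated chain carbon, eight bonds along the chain from an aromatic nitrogen, gives an at least 4.3-fold lower number from compound 2 to compound 4 (0.63 log units; beyond the scatter) and points the same way on both cores, though its exact size on each stays unknown: the same change on two cores in this assay, an at least 2.5-fold lower number (0.40 log units; beyond the scatter) from compound 1 to compound 3 and an at least 4.3-fold lower number (0.63 log units; beyond the scatter) from compound 2 to compound 4; the limit leaves it open whether they differ.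

The compounds shown leave open whether a still longer chain would keep lowering the number. They also leave open how methylamino or morpholine would behave in place of amino, and how a carboxylic acid would behave in place of the hydroxyl.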